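Methyl Added to the Isopropyl Chain: Compound 4 Awaits Measurement

The source may report more compounds than this note shows. Statements on the series, on what has been measured and on what is new or still open speak of the compounds shown alone.

Compound 1 `COc1ccc(NC(=O)C(=O)c2cn(C(C)C)c3ccccc23)cn1` — 85 nM
Compound 2 `CC(C)n1cc(C(=O)C(=O)Nc2cccnc2)c2ccccc21` — > 10000 nM
Compound 3 `COc1ccc(NC(=O)C(=O)c2cn(C(C)C)c3c(OC)cccc23)cn1` — > 10000 nM

Going by the values given here, compound 1 holds the only real number in a functional assay on FaDu cells (Homo sapiens) for cytotoxicity, read by MTT assay, with a stated time of 72 h (a higher number here means that more compound is tolerated, a lower number that less compound is tolerated), at 85 nM. Compound 2 sits at a limit of the assay, > 10000 nM. Compound 3 likewise sits at a limit, > 10000 nM. Both measured steps are large, an at least 110-fold higher number from compound 1 to compound 2 (2.07 log units; beyond the scatter) and an at least 110-fold higher number from compound 1 to compound 3 (2.07 log units; beyond the scatter), and both end at the limit of > 10000 nM in this assay, at which 2 of the 3 values shown sit. Compound 4 `CCC(C)n1cc(C(=O)C(=O)Nc2ccc(OC)nc2)c2ccccc21` differs from compound 1 by methyl in place of hydrogen on a saturated chain carbon, two bonds along the chain from an aromatic nitrogen. Both measured steps change a methoxy on an aromatic carbon; neither touches the isopropyl chain, so neither bears directly on this change. A step no larger than the scatter is therefore expected, in either direction: a 1.8-fold higher number from compound 1 to compound 4 (0.25 log units; within the scatter). Compound 4 is estimated at 150 nM, within 40 nM to 1500 nM.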

Compound 4, concentration lethal to 50% of the cells: 68 nM
For compound 4 the middle estimate is 2.2-fold (0.34 log units) above the measured one; measured number inside the range.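

In this assay, replacing isopropyl with sec-butyl gives a 1.3-fold lower number from compound 1 to compound 4 (0.10 log units; within the scatter). Unlike the two methoxy changes, this one shows that the saturated chain carbon, two bonds along the chain from an aromatic nitrogen, can carry an added methyl without a step beyond the scatter. Nothing shown gives a cause for this result. The compounds shown leave open how far this tolerance extends, since one added methyl is the only change at this place. As far as these compounds go, what a longer chain or an amine here would do remains unknown.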